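This account rests on a few compounds, and the source may have more. Where it says the series, first, only, none or still open, it means among the compounds named here.

Compound 1 `COc1cc(/C=C2\SC(=O)NC2=O)ccc1OCN1C(=O)c2ccccc2C1=O` gives 35100 nM in an assay on isolated protein for inhibition of Alpha glucosidase (Homo sapiens), read by spectrophotometry, with stated times of 15 min and 30 min; on this read-out higher numbers stand for weaker inhibition and lower numbers for stronger inhibition.
Compound 2 `CCOc1cc(/C=C2\SC(=O)NC2=O)ccc1OCN1C(=O)c2ccccc2C1=O` gives 29300 nM in this assay.

Among these two numbers compound 1 stands highest, with compound 2 nearest: a 1.2-fold lower number from compound 1 to compound 2 (0.08 log units; within the scatter). Compound 3 `COc1cc(/C=C2\SC(=O)NC2=O)cc(OC)c1OCN1C(=O)c2ccccc2C1=O` differs from compound 1 in one place, (methoxy in place of hydrogen on an aromatic carbon), that is, methoxy in place of hydrogen on an aromatic carbon of the six-membered aromatic ring of carbon only. For the measured compounds named here, the single measured step, a 1.2-fold lower number from compound 1 to compound 2 (0.08 log units; within the scatter), changes a saturated chain carbon bound to the ring oxygen, not the aromatic ring, and it stays within the scatter. Going by the values given here, no measured step covers a second methoxy on the ring, so the shared core and the measured pair give no ground to expect movement in this assay beyond the scatter in either direction. Compound 3 is therefore estimated at 32000 nM, with a range from 12000 nM to 90000 nM. That estimate means an expected step of a 1.1-fold lower number from compound 1 to compound 3 (0.04 log units; within the scatter).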

Compound 3, half-maximal inhibitory concentration: > 100000 nM
Compound 3 gave a limit, no number; the forecaster's own chance of this, stated with the estimate: 10%; at least 3.1-fold (0.49 log units) between middle value and limit.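

For the compounds shown here, the aromatic ring turns out to be sensitive to substitution in a way the earlier pair could not show: the only earlier change, on the saturated chain carbon, gave a 1.2-fold lower number from compound 1 to compound 2 (0.08 log units; within the scatter). Methoxy in place of hydrogen on this aromatic carbon, ortho to a large group and meta to a methoxy group, gives an at least 2.8-fold higher number from compound 1 to compound 3 (0.45 log units; beyond the scatter), which marks this position as one where the added group weakens inhibition. Compound 3 gives a limit and not a number in this assay: the limit of > 100000 nM in this assay, at which 1 of the 3 values shown sits.

From the compounds shown here alone, with one group on one aromatic carbon, it remains open whether this loss belongs to methoxy itself or to any group placed there, such as a hydroxyl or a fluorine. Going by these compounds, it also remains open whether the same change would act alike on the ethoxy group of compound 2.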